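Swapping 3-chlorophenyl for 4-bromophenyl

The source may hold more compounds than are shown below. What is called first, only, known or untested is meant among the compounds shown, and "the series" means these compounds.

In a functional assay on HCT-116 cells (Homo sapiens) for antiproliferative activity, read by MTT assay, with a stated time of 72 h (a lower number here means a stronger inhibitor, a higher number a weaker inhibitor), compound 1 (`NC1=NC2(CCSCC2)N(OCCCOc2ccc(Cl)c(Cl)c2)C(N)=N1`) gives 1 nM, and compound 2 (`NC1=NC2(CCSCC2)N(OCCCOc2cccc(Cl)c2)C(N)=N1`) gives 1 nM, so compound 2 stands level with compound 1. The next compound to be tested is compound 3 (`NC1=NC2(CCSCC2)N(OCCCOc2ccc(Br)cc2)C(N)=N1`), which has 4-bromophenyl in place of 3-chlorophenyl on an oxygen on a saturated carbon.

Within the data shown here, only one measured step offers any guidance. Putting hydrogen in place of chloro on an aromatic carbon gave no change at the digits printed from compound 1 to compound 2 (within the scatter). That step shows that the second chloro of compound 1 could go without a measurable difference in this assay. It is only a partial guide, however, since neither measured compound carries a bromo group or a 4-substituted phenyl. The expectation therefore leans only slightly toward a weaker inhibitor, and the range is kept wide. The expected size of the change is a 2.0-fold higher number from compound 2 to compound 3 (0.30 log units; within the scatter). For compound 3 the estimated value is 2 nM, with an expected range from 0.6 nM to 7 nM.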

Compound 3, half-maximal inhibitory concentration: 20 nM
Beside the measured number, compound 3's estimate is 10-fold (1.00 log units) below it, and the stated range ends below it.
By their numbers in this assay, from the lowest: compounds 1 and 2 (each within the scatter of the next); then compound 3.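

In this assay, the earlier pair suggested that this aromatic group tolerates change, since removing a chloro made no difference at the digits printed, but the new result shows that this tolerance has clear limits: 4-bromophenyl in place of 3-chlorophenyl gives a 20-fold higher number from compound 2 to compound 3 (1.30 log units; beyond the scatter), and 4-bromophenyl in place of 3,4-dichlorophenyl gives a 20-fold higher number from compound 1 to compound 3 (1.30 log units; beyond the scatter). The leaving and entering groups match in their heavy-atom counts and hydrogen-bond donor and acceptor counts and carry no net charge, so these simple counts do not separate a strong inhibitor from a clearly weaker one here. No measured evidence is available to explain the loss of activity.

The swap changes both the halogen and its place on the ring, so these compounds cannot show whether chlorine giving way to bromine, the new position or both together produce the large step. Going by these compounds, how a plain phenyl, a methoxy-bearing phenyl or an amine-bearing phenyl would behave at this oxygen also remains open, as does the effect of a longer chain between the core and the aromatic ring.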